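Trimming the Amide Substituent from Cyclohexyl to Isopropyl

The source may report more compounds than this note shows. Statements on the series, on what has been measured and on what is new or still open speak of the compounds shown alone.

Measured so far in a functional assay on the whole organism for inhibition, with Rattus norvegicus as the target, read by paw edema, with stated times of 30 min and 3 h, at a dose of 0.28 mmol/kg by the oral route; a higher number here means more inhibition at the dose given (going by the name of the read-out), a lower number less inhibition:
compound 1, `CC(=O)c1ccc(NC(=O)c2nc(-c3ccccc3)n(-c3ccc(S(N)(=O)=O)cc3)n2)cc1`, 73%
compound 2, `NS(=O)(=O)c1ccc(-n2nc(C(=O)NC3CCCCC3)nc2-c2ccccc2)cc1`, 65%

Compound 2 stands lowest of the two numbers, with compound 1 nearest, a gap within the scatter. Compound 3, `CC(C)NC(=O)c1nc(-c2ccccc2)n(-c2ccc(S(N)(=O)=O)cc2)n1`, has not been measured; it differs from compound 2 by isopropyl in place of cyclohexyl on an amide-type nitrogen. Within the data shown here, the one measured step that bears on this position is a number 8 percentage points lower from compound 1 to compound 2 (within the scatter), and it stayed within the scatter. An alkyl-for-alkyl change at the same amide nitrogen is therefore expected to give no step beyond the scatter, namely a number 7 percentage points lower from compound 2 to compound 3 (within the scatter). Compound 3 is estimated at 58%, in the range 42% to 74%.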

Compound 3, a percentage reported as inhibition, in the whole organism at one dose (the size of the read-out at that dose, not a potency): 55%
Compound 3: the middle estimate sits 3 percentage points above what was measured; measured number inside the range.
By their numbers in this assay, from the lowest: compounds 3, 2 and 1 (each within the scatter of the next, the first and the last beyond it).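

Exchanging cyclohexyl for isopropyl on the amide-type nitrogen gives a step that does not separate the two compounds in this assay (a number 10 percentage points lower from compound 2 to compound 3 (within the scatter)). Among these compounds, the position still matters to the read-out: isopropyl in place of 4-acetylphenyl gives the first step at this nitrogen to lie beyond the scatter (a number 18 percentage points lower from compound 1 to compound 3 (beyond the scatter)), although compound 2 stays within the scatter of both other compounds. No evidence is available to explain these differences.

Still open, going by these compounds, is how a longer alkyl chain, a benzyl group or a carboxylic acid on this nitrogen would read in this assay.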